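The compounds below may be only part of what the source reports. "The series", "measured", "known", "first", "only" and "open" are said of these compounds alone.

Measured compounds:

- compound 1, `CNC(=O)c1cc(Oc2ccc3nc(Nc4cccc(C(C)(C)C)c4)cnc3c2)ccn1`: < 1000 nM
- compound 2, `CNC(=O)c1cc(Oc2ccc3nc(Nc4ccccc4Oc4ccccc4)ncc3c2)ccn1`: < 1000 nM
- compound 3, `CNC(=O)c1cc(Oc2ccc3nc(Nc4cccc(Br)c4)ncc3c2)ccn1`: < 1000 nM

The three compounds share one core and differ only in the aryl group on the nitrogen on the aromatic ring. In a physicochemical assay for solubility, at pH 7 (on this read-out lower numbers stand for lower solubility and higher numbers for higher solubility), compound 1 gives < 1000 nM, which is a limit of the assay and not a number. In this assay compound 2 gives < 1000 nM, again a limit. In this assay compound 3 gives < 1000 nM, also a limit. Among the measured compounds shown here, compound 3 therefore stands where every value shown stands, at the limit of < 1000 nM in this assay, at which 3 of the 3 values shown sit; no compound here can be set above or below another.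

Compound 4, `CNC(=O)c1cc(Oc2ccc3nc(Nc4ccc(OC(F)(F)F)cc4)ncc3c2)ccn1`, differs from compound 3 in one place: 4-(trifluoromethoxy)phenyl in place of 3-bromophenyl on a nitrogen on an aromatic ring.

For the measured compounds named here, no step between two measured compounds is available, since none of the three values is a number. The step from compound 3 to compound 4 in this assay is expected to be none beyond the scatter, a step that the limit leaves unreadable from compound 3 to compound 4, with the aryl group on the nitrogen exchanged once more and the other three such groups all sitting at the same limit. Compound 4 is estimated at 500 nM, within a range of 100 nM to 2000 nM, and it is expected that this assay may again report only a limit for compound 4.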

Compound 4, solubility: < 1000 nM
Compound 4: only a limit was reported; the forecaster's own chance of this, stated with the estimate: 70%; the middle value does not contradict the limit.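

In this assay compound 4 gives < 1000 nM, which is a limit and not a number. No step can be read from compound 3 to compound 4, as neither value is a number, and all the compounds shown stand together: the limit of < 1000 nM in this assay, at which 4 of the 4 values shown sit. The compounds shown leave open how their solubilities compare with one another.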